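The source may report more compounds than this note shows. Statements on the series, on what has been measured and on what is new or still open speak of the compounds shown alone.

Compound 1, `C=CC1=C(C(=O)Nc2ccccc2OC)C(c2ccc(F)cc2)OC1`: > 100000 nM
Compound 2, `C=CC1=C(C(=O)Nc2ccccc2OC)C(c2ccc(OC)cc2)OC1`: > 100000 nM
Compound 3, `C=CC1=C(C(=O)NCCC)C(c2ccc(Cl)c(Cl)c2)OC1`: > 100000 nM

All three share one core and were tested in a functional assay on SW480 cells (Homo sapiens) for cytotoxicity, read by MTT assay, with a stated time of 24 h; a higher number here means a weaker inhibitor, a lower number a stronger inhibitor. Compound 1 gives only a limit in this assay, not a number. Compound 2 likewise sits at a limit. Compound 3, which carries a propyl on the amide nitrogen, also sits at a limit. Among the compounds with values here, the one step between neighbours, a step that the two limits leave unreadable from compound 1 to compound 2, cannot be read because the limit of > 100000 nM in this assay, at which 3 of the 3 values shown sit, is where both of its compounds stand.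

Compound 4, `C=CC1=C(C(=O)NCc2ccc(C)cc2)C(c2ccc(F)cc2)OC1`, is the next compound in this assay. It differs from compound 1 in one place: 4-methylbenzyl in place of 2-methoxyphenyl on an amide-type nitrogen. Within the data shown here, no measured step touches the amide nitrogen, so nothing read so far speaks for or against this change; the only hint is that compound 3, with a different group on that nitrogen, also gave no number. Compound 4 is therefore expected to sit at or past the same limit, with an estimate of 150000 nM and a range from 40000 nM to 600000 nM. The step from compound 1 is expected to be a step that the limit leaves unreadable from compound 1 to compound 4, which is not readable against a limit.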

Compound 4, half-maximal inhibitory concentration: > 100000 nM
Compound 4: a limit, no number (the forecaster's own chance of this, stated with the estimate: 80%); the middle value lies beyond the limit too.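

Compound 4, like compound 1, gives only a limit in this assay, so no step from compound 1 to compound 4 can be read: the limit of > 100000 nM in this assay, at which 4 of the 4 values shown sit.

The compounds shown leave open whether any group on the amide-type nitrogen would give a number rather than a limit in this assay.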